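Removing a Nitro Group from a Dose-Response Series in Mice

The compounds below may be only part of what the source reports. "The series", "measured", "known", "first", "only" and "open" are said of these compounds alone.

Compound 1 `COc1cc2c(cc1OC)C(c1ccc([N+](=O)[O-])cc1)=NN(C)C(=S)C2` — 81.5 umol/kg
Compound 2 `COc1cc2c(cc1OC)C(c1cccc(N)c1)=NNC(=O)C2` — 18.3 umol/kg
Compound 3 `COc1cc2c(cc1OC)C(c1ccc(Cl)cc1)=NN=C(S)C2` — 55 umol/kg

Three compounds sharing one core were examined in a functional assay on the whole organism with Mus musculus as the target; on this read-out higher numbers stand for an effect only at larger amounts of compound and lower numbers for an effect already at smaller amounts. Compound 1 gives 81.5 umol/kg, the highest of the three numbers. Compound 3 gives 55 umol/kg, and the gap between it and compound 1 lies within the scatter, so no order can be read between these two. Compound 2 gives 18.3 umol/kg, and this gap to compound 1 lies beyond the scatter.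

Compound 4 `COc1cc2c(cc1OC)C(c1ccccc1)=NN(C)C(=S)C2` has not yet been measured in this assay. It differs from compound 1 in one place: hydrogen in place of nitro on an aromatic carbon. No measured pair in this set isolates that change, so the expectation rests only on the spread of the three numbers shown. Given that compound 1 sits at 81.5 umol/kg, the higher end of the set, a modest step toward lower numbers is expected, a 1.5-fold lower number from compound 1 to compound 4 (0.17 log units; within the scatter), though it may not exceed the scatter. Compound 4 is estimated at 55 umol/kg, within 25 umol/kg to 120 umol/kg.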

Compound 4, dose for half-maximal effect: 24.7 umol/kg
Estimate against measurement, compound 4: 2.2-fold (0.35 log units) above, and the stated range ends above it.
By their numbers in this assay, from the lowest: compounds 2 and 4 (each within the scatter of the next); then compounds 3 and 1 (each within the scatter of the next).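

Swapping nitro for hydrogen on the aromatic carbon para to a large group gives, in this assay, a 3.3-fold lower number from compound 1 to compound 4 (0.52 log units; beyond the scatter), and this is the first comparison in the set that isolates a single change. The step lies beyond the scatter, so on the core of compound 1 the nitro group is not required for an effect in the whole animal, and the unsubstituted ring responds at smaller amounts of compound. Nothing available here bears on why the number moves with this change.

The compounds shown leave open how other groups at this same place, such as a carboxylic acid or a trifluoromethyl group, would compare with hydrogen and nitro. Compound 2 and compound 3 each differ from compound 4 in more than one place, so the contribution of the other parts of the core also remains unresolved.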